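The source may hold more compounds than are shown below. What is called first, only, known or untested is meant among the compounds shown, and "the series" means these compounds.

Of the compounds shown here, two from this study have so far been measured in a functional assay on Ehrlich cells (Homo sapiens) for cytotoxicity, read by MTT assay, with a stated time of 48 h; on this read-out lower numbers stand for stronger inhibition and higher numbers for weaker inhibition. Compound 1 `Cc1noc2c1N=C(c1ccccc1)CC(c1ccccc1)C2C(c1ccc(Cl)cc1)C1c2onc(C)c2N=C(c2ccccc2)CC1c1ccccc1` gives 60.4 ug/mL in this assay. Compound 2 `Cc1ccc(C2CC(c3ccccc3)=Nc3c(C)noc3C2C(c2ccccc2)C2c3onc(C)c3N=C(c3ccccc3)CC2c2ccc(C)cc2)cc1` gives 51.6 ug/mL in this assay. Compound 1 thus stands alongside compound 2, the gap between them within the usual scatter, so no ordering of the two can be claimed. Compound 3 `Cc1noc2c1N=C(c1ccccc1)CC(c1ccccc1)C2C(c1ccccc1)C1c2onc(C)c2N=C(c2ccccc2)CC1c1ccccc1` has not yet been measured. It differs from compound 1 in one place: hydrogen in place of chloro on an aromatic carbon, in other words hydrogen in place of chloro on an aromatic carbon. For the measured compounds named here, no pair of measured compounds shows a step of this kind, so the data give no direct guide to its size. What can be said is that compound 2 differs from compound 1 at several places and still lands within the scatter, because compound 2 gives 51.6 ug/mL while compound 1 gives 60.4 ug/mL. The expected step of a 1.1-fold higher number from compound 1 to compound 3 (0.03 log units; within the scatter) is therefore small, in no particular direction, and likely within the scatter. Compound 3 is estimated at 65 ug/mL, with a range from 35 ug/mL to 115 ug/mL.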

Compound 3, half-maximal inhibitory concentration: 66.5 ug/mL
For compound 3 the middle estimate is 1.0-fold (0.01 log units) below the measured one; low and high end bracket the measured number.
By their numbers in this assay, from the lowest: compounds 2, 1 and 3 (each within the scatter of the next).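

Taking the chloro off the aromatic carbon, so that 4-chlorophenyl becomes phenyl, gives a 1.1-fold higher number from compound 1 to compound 3 (0.04 log units; within the scatter) in this assay, the first direct reading of a single change in this series. At this place, para to a large group, losing this one heavy atom therefore leaves no difference that can be told apart from the ordinary variation between repeated measurements, so the chloro is not shown to matter for this read-out. No measurement in hand speaks to what lies behind this outcome.

Only chloro and hydrogen can be compared at this place, so a group of another kind, such as an amine, a carboxylic acid or a longer alkyl chain, might still shift the number in either direction or might leave it where it is. As far as these compounds go, it also remains open whether swapping chloro for hydrogen on one of the other aromatic rings of the shared core would give a similarly small step.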